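Acrylamide in Place of Chloropropyl Amide: Predicting Compound 4

A few compounds are considered here, and "the series" means these few. Any claim that something is new, unique, unknown or untested is made for them only; others in the source may bear on it.

compound 1 `CC(C)(C)c1ccc(NC(=O)CCCCl)cc1` — > 100000 nM
compound 2 `CC(C)(C)c1ccc(CNC(=O)CCCCl)cc1` — 92000 nM
compound 3 `C=CC(=O)Nc1ccc(C(C)(C)C)cc1` — 29000 nM

In a functional assay on MCF7 cells (Homo sapiens) for antiproliferative activity, with a stated time of 48 h (on this read-out higher numbers stand for weaker inhibition and lower numbers for stronger inhibition), compound 1 reaches only a limit of the assay, > 100000 nM (the limit of > 100000 nM in this assay, at which 1 of the 3 values shown sits). Compound 3 gives 29000 nM. The change between them, (vinyl in place of 3-chloropropyl on a carbonyl carbon), brings an at least 3.4-fold lower number from compound 1 to compound 3 (0.53 log units; beyond the scatter). Compound 2 gives 92000 nM, the highest measured number among the two compounds with a number. How the core of compound 2 differs from the core of compound 1 is not broken down here. Compound 4 `C=CC(=O)NCc1ccc(C(C)(C)C)cc1` carries the same change as compound 3, namely (vinyl in place of 3-chloropropyl on a carbonyl carbon); the surroundings of the place are described in the same words, so this is the same change. Compound 4 is therefore expected to give about 30000 nM, within 10000 nM to 90000 nM. That step is expected to be a 3.1-fold lower number from compound 2 to compound 4 (0.49 log units; beyond the scatter), which rests on the measured step of an at least 3.4-fold lower number from compound 1 to compound 3 (0.53 log units; beyond the scatter).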

Compound 4, half-maximal inhibitory concentration: > 100000 nM
Compound 4 gave a limit, no number; the forecaster's own chance of this, stated with the estimate: 10%; middle value at least 3.3-fold (0.52 log units) away from the limit.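

In this assay compound 4 reaches only a limit of the assay, > 100000 nM, and not a number. Putting vinyl in place of 3-chloropropyl on the carbonyl carbon gives an at least 1.0-fold higher number from compound 2 to compound 4 (0.03 log units; that floor lies within the scatter), so the lower number seen on the core of compound 1 does not carry over to the core of compound 2: the same change on two cores in this assay, an at least 3.4-fold lower number (0.53 log units; beyond the scatter) from compound 1 to compound 3 and an at least 1.0-fold higher number (0.03 log units; that floor lies within the scatter) from compound 2 to compound 4, at least 3.7-fold (0.57 log units) apart, beyond the scatter of two such steps. This does not show the true size of the step on the core of compound 2, nor why the two cores part ways, and two cores give no general rule: the limit of > 100000 nM in this assay, at which 2 of the 4 values shown sit.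

Going by these compounds, it remains open how an ethyl group or a longer chain on the same carbonyl carbon would read out on either core. On these data alone, a carboxylic acid or an amine at the end of the chain is equally open.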